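A Bromo for Chloro Swap on Compound 1

The source may report more compounds than this note shows. Statements on the series, on what has been measured and on what is new or still open speak of the compounds shown alone.

In a functional assay on NCI-H460 cells (Homo sapiens) for inhibition, read by CCK-8 assay, with a stated time of 72 h, tested at 10 uM (a lower number here means less inhibition of growth, a higher number more inhibition of growth at the concentration tested), compound 1 `CN(C)C(=O)c1cc2cnc(Nc3ccc(NC(=O)C4(C(=O)Nc5ccc(Cl)cc5)CC4)cc3)nc2n1C1CCCC1` gives 95.7%. Among the measured compounds shown here, the only other measured analogue, compound 2 `CN(C)C(=O)c1cc2cnc(Nc3ccc(NC(=O)C4(C(=O)Nc5ccccc5F)CC4)cc3)nc2n1C1CCCC1`, gives 93.1%, so compound 1 has no measured neighbour outside the scatter. Compound 3 `CN(C)C(=O)c1cc2cnc(Nc3ccc(NC(=O)C4(C(=O)Nc5ccc(Br)cc5)CC4)cc3)nc2n1C1CCCC1` has not yet been measured. It differs from compound 1 by bromo in place of chloro on an aromatic carbon, which places bromo in place of chloro on an aromatic carbon, para to a large group. For the measured compounds named here, one measured step bears on this change, as it alters the same 4-chlorophenyl group: replacing it with 2-fluorophenyl gives a number 2.6 percentage points lower from compound 1 to compound 2 (within the scatter). Going by the values given here, that is a single, different replacement, so it offers only modest guidance, and no measured step exchanges chloro for bromo. No shift beyond the scatter is expected in this assay. The estimated change is a number 0.7 percentage points lower from compound 1 to compound 3 (within the scatter). For compound 3 the expected value is 95%, with an estimated range of 88% to 100%.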

Compound 3, percent growth inhibition at one concentration: 96.4%
Compound 3: the middle estimate sits 1.4 percentage points below what was measured, and the stated range covers the measured number.
By their numbers in this assay, from the lowest: compounds 2, 1 and 3 (each within the scatter of the next).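

In this assay, among the compounds shown here, the first exchange of one halogen for another at this place, on an aromatic carbon para to a large group, gives a number 0.7 percentage points higher from compound 1 to compound 3 (within the scatter) and so leaves the read-out within the scatter. The step from the 2-fluorophenyl analogue to the 4-bromophenyl analogue, a number 3.3 percentage points higher from compound 2 to compound 3 (within the scatter), also stays within the scatter, so the three aryl amides shown cannot be told apart in this assay. No measured evidence accounts for the similarity of these values.

Going by these compounds, what remains open is whether this place would accept a group of another kind, such as an amine, a carboxylic acid or a methoxy group, without a step beyond the scatter. On these data alone, it also remains open whether compound 1 and compound 3 would separate at a lower tested concentration.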